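The source may report more compounds than this note shows. Statements on the series, on what has been measured and on what is new or still open speak of the compounds shown alone.

Among the compounds with values here, compound 1 `CC1=C/C(=C\C(C)C)C(=O)C(C)(O)C12CC2` gives 300 nM in a functional assay on MDA-MB-231 cells (Homo sapiens) for antiproliferative activity (a higher number here means a weaker inhibitor, a lower number a stronger inhibitor), the lowest of the two numbers measured so far; compound 2 `CC1=C/C(=C\C#CCCO)C(=O)C(C)(O)C12CC2` gives 2000 nM in this assay, the step being a 6.7-fold higher number from compound 1 to compound 2 (0.82 log units; beyond the scatter). Compound 3 `C=C/C=C1\C=C(C)C2(CC2)C(C)(O)C1=O` differs from compound 1 in one place: vinyl in place of isopropyl on a double-bonded chain carbon bound to a double-bonded ring carbon. Within the data shown here, the only measured step at that place is a 6.7-fold higher number from compound 1 to compound 2 (0.82 log units; beyond the scatter), which bears on the new change only indirectly, since what enters there is a different group. A modest loss is therefore expected for compound 3, a 2.3-fold higher number from compound 1 to compound 3 (0.37 log units; beyond the scatter). The estimate for compound 3 is 700 nM, with a range from 300 nM to 1800 nM.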

Compound 3, half-maximal inhibitory concentration: 28 nM
For compound 3 the middle estimate is 25-fold (1.40 log units) above the measured one; the whole stated range lies above it.
By their numbers in this assay, from the lowest: compound 3; then compound 1; then compound 2.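

At this place, on a double-bonded chain carbon bound to a double-bonded ring carbon, an 11-fold lower number from compound 1 to compound 3 (1.03 log units; beyond the scatter) shows that vinyl gains strongly over isopropyl, so the change can improve the number as well as worsen it. The spread across the groups shown is wide: a 71-fold lower number from compound 2 to compound 3 (1.85 log units; beyond the scatter) is the largest step in the series so far. No evidence on hand accounts for this gain.

Still open, as far as these compounds go, is whether the gain requires the vinyl double bond or only the two-carbon size, a question that ethyl would address. Whether a longer conjugated chain, such as buta-1,3-dienyl, or a phenyl group goes further also remains unresolved.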